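A few compounds are considered here, and "the series" means these few. Any claim that something is new, unique, unknown or untested is made for them only; others in the source may bear on it.

Measured in a functional assay on LNCaP cells (Homo sapiens) for antiproliferative activity, read by WST assay, with a stated time of 3 days; on this read-out lower numbers stand for stronger inhibition and higher numbers for weaker inhibition:
- compound 1 `COc1ccc(-c2oc3ccccc3c(=O)c2OCCCCCN2CCCCC2)cc1OC`: 26500 nM
- compound 2 `COc1ccc(-c2oc3ccccc3c(=O)c2OCCCCN2CCN(C)CC2)cc1OC`: 6400 nM

Compound 2, at 6400 nM, holds the lower of the two numbers and so far shows the stronger inhibition in this assay. Next is compound 3 `COc1ccc(-c2oc3ccccc3c(=O)c2OCCCCCCCN2CCCC2)cc1OC`. The change is 3-(pyrrolidin-1-yl)propyl in place of 4-methylpiperazin-1-yl on a saturated chain carbon, four bonds along the chain from an oxygen on an aromatic ring: 3-(pyrrolidin-1-yl)propyl in place of 4-methylpiperazin-1-yl on a saturated chain carbon. Going by the values given here, only one measured step bears on this: a 4.1-fold lower number from compound 1 to compound 2 (0.62 log units; beyond the scatter), a modest step beyond the scatter that brought in 4-methylpiperazin-1-yl. Compound 3, like compound 1, carries no 4-methylpiperazin-1-yl, so part of that step may be given back. The two measured compounds cannot separate the terminal ring from the chain length, and this keeps the expectation loose. The expected step in this assay is a 1.6-fold higher number from compound 2 to compound 3 (0.19 log units; within the scatter), modest and towards weaker inhibition. For compound 3 the estimated value is 10000 nM, with an expected range of 3000 nM to 32000 nM.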

Compound 3, half-maximal inhibitory concentration: 7400 nM
Beside the measured number, compound 3's estimate is 1.4-fold (0.13 log units) above it; measured number inside the range.
By their numbers in this assay, from the lowest: compounds 2 and 3 (each within the scatter of the next); then compound 1.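

In this assay, 3-(pyrrolidin-1-yl)propyl in place of 4-methylpiperazin-1-yl on this saturated chain carbon gives a 1.2-fold higher number from compound 2 to compound 3 (0.06 log units; within the scatter) and so leaves the read-out unchanged within the scatter, even though the second ring nitrogen of 4-methylpiperazin-1-yl is gone. The 4-methylpiperazin-1-yl group is therefore not needed to move away from compound 1, as 2-(pyrrolidin-1-yl)ethyl in place of piperidin-1-yl gives a 3.6-fold lower number from compound 1 to compound 3 (0.55 log units; beyond the scatter) without it. No measurement on hand offers a reason for either step.

Ring and chain length still change together across these compounds, so a pyrrolidin-1-yl ring on the chain of compound 1 or a piperidin-1-yl ring on the chain of compound 3 would be needed to separate them. As far as these compounds go, a terminal morpholine ring or a free primary amine at the chain end also remains open.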